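The source may report more compounds than this note shows. Statements on the series, on what has been measured and on what is new or still open speak of the compounds shown alone.

In an ADME assay on BJ cells (Homo sapiens) for cytotoxicity, read by CellTiter-Glo and resazurin assay, with a stated time of 72 h (on this read-out higher numbers stand for an effect only at larger amounts of compound and lower numbers for an effect already at smaller amounts), the measured compounds read as follows.
Compound 1 `CC(C)N(Cc1cccc(OCCCCCC(=O)O)c1)C(=O)c1ccc(-c2cccc3ccccc23)cc1` gives < 1.3 nM, which is a limit of the assay.
Compound 2 `CC(=O)Nc1cccc(-c2ccc(C(=O)N(Cc3cccc(OCCCCCC(=O)O)c3)C(C)C)cc2)c1` gives > 26000 nM, also a limit.
Compound 3 `CC(C)N(Cc1cccc(OCCCCCC(=O)O)c1)C(=O)c1ccc(-c2ccsc2)cc1` gives > 26000 nM, also a limit.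

Compound 1 stands only at a limit, the low end of what this assay reports (the limit of < 1.3 nM in this assay, at which 1 of the 3 values shown sits), while the other two sit at the high end (the limit of > 26000 nM in this assay, at which 2 of the 3 values shown sit). Compound 4 `COc1ccc(F)c(-c2ccc(C(=O)N(Cc3cccc(OCCCCCC(=O)O)c3)C(C)C)cc2)c1` differs from compound 1 in one place: 2-fluoro-5-methoxyphenyl in place of naphthalen-1-yl on an aromatic carbon. Both measured steps from compound 1 removed the naphthalen-1-yl group and both were large: an at least 20000-fold higher number from compound 1 to compound 2 (4.30 log units; beyond the scatter) and an at least 20000-fold higher number from compound 1 to compound 3 (4.30 log units; beyond the scatter). Compound 4 loses the naphthalen-1-yl group as well, so a large rise in this assay is expected, probably again up to a limit. The expected value for compound 4 is 20000 nM, with a range from 500 nM to 60000 nM. This corresponds to an expected step of an at least 15000-fold higher number from compound 1 to compound 4 (4.18 log units; beyond the scatter).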

Compound 4, half-maximal effective concentration: > 26000 nM
Compound 4: only a limit was reported (the forecaster's own chance of this, stated with the estimate: 60%); middle value at least 1.3-fold (0.11 log units) away from the limit.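

In this assay, replacing naphthalen-1-yl with 2-fluoro-5-methoxyphenyl gives an at least 20000-fold higher number from compound 1 to compound 4 (4.30 log units; beyond the scatter). The entering group has nearly as many heavy atoms as the one it replaces but one six-membered aromatic ring instead of two, so similar size alone does not preserve the low number in this series. The steps among compound 2, compound 3 and compound 4 cannot be read, because all three values are the same assay limit: the limit of > 26000 nM in this assay, at which 3 of the 4 values shown sit.

As far as these compounds go, whether the low number requires naphthalen-1-yl itself remains open. A naphthalen-2-yl or quinolin-8-yl group at this position would test that.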